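The compounds below may be only part of what the source reports. "The series", "measured", "known", "first", "only" and "open" are said of these compounds alone.

Of the compounds shown here, three from one series have been measured in a physicochemical assay for lipophilicity, measured as octanol-water partition; on this read-out higher numbers stand for higher lipophilicity and lower numbers for lower lipophilicity. Compound 1, `CC1=C(C(=O)OCc2cccnc2)C(c2ccccc2[N+](=O)[O-])C2=C(CCCC2=O)N1`, gives 1.51, which is the second highest of the three numbers. Compound 2, `CC1=C(C(=O)OCc2ccccn2)C(c2ccco2)C2=C(CCCC2=O)N1`, gives 1.4, a number that sits within the scatter of compound 1. Compound 3, `COc1cc(C2C(C(=O)OCc3ccccn3)=C(C)NC3=C2C(=O)CCC3)cc(OC)c1OC`, gives 2.17, a number that lies beyond the scatter above compound 1. Among the compounds with values here, no two of the measured compounds differ in only one place, so no single structural step has yet been tied to a change in this assay.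

Compound 4, `CC1=C(C(=O)OCc2cccnc2)C(c2cccs2)C2=C(CCCC2=O)N1`, has not been measured. It is related to compound 1 by one change: thiophen-2-yl in place of 2-nitrophenyl on a saturated ring carbon. The core of compound 1 and the ester side are kept.

For compound 4 a small upward step in this assay from compound 1 is expected, close to the edge of the scatter, as a number 0.19 log units higher from compound 1 to compound 4 (within the scatter). The expectation is kept moderate because compound 2, with another five-membered ring in the same place, gives 1.4. Compound 4 is estimated at 1.7 in this assay, within a range from 1.35 to 2.05.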

Compound 4, partition coefficient: 1.4
The estimate for compound 4 lay 0.30 log units above the measured number; the measured number falls inside the stated range.
By their numbers in this assay, from the lowest: compounds 2, 4 and 1 (each within the scatter of the next); then compound 3.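

In this assay, within the data shown here, putting thiophen-2-yl in place of 2-nitrophenyl on this saturated ring carbon gives a number 0.11 log units lower from compound 1 to compound 4 (within the scatter) and is the only single change available so far in which the core of compound 1 and the ester side stay fixed. This place on the ring therefore accepts a large change in the group it carries, with 5 heavy atoms entering where 9 leave and a five-membered aromatic ring replacing a six-membered one, and still no difference beyond the usual scatter appears. No measurement in hand gives a reason for this result.

Among these compounds, this single step tests only one pair of groups at one place, so it cannot show whether every group here would leave the number within the scatter, and an amine or a carboxylic acid on the same ring carbon remains an open case. Compound 3 differs from compound 1 in more than one place, so what lies behind its separate position in this series also remains open.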